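The compounds below may be only part of what the source reports. "The series", "measured", "known", "first", "only" and "open" are said of these compounds alone.

Measured compounds so far:
compound 1, `O=S(=O)(Nc1ccc2oc(-c3ccccc3)nc2c1)c1ccccc1O`, gives 33000 nM;
compound 2, `O=S(=O)(Nc1ccc2oc(-c3ccccc3)nc2c1)c1ccccc1Cl`, gives 73000 nM;
compound 3, `Cc1cccc(S(=O)(=O)Nc2ccc3oc(-c4ccccc4)nc3c2)c1`, gives 69000 nM.

In an ADME assay on HEK293 cells (Homo sapiens) for cytotoxicity, read by resazurin assay, with a stated time of 48 h (a higher number here means that more compound is tolerated, a lower number that less compound is tolerated), compound 3 stands second highest of the three numbers. Its nearest neighbour is compound 2: a 1.1-fold lower number from compound 2 to compound 3 (0.02 log units; within the scatter). Its furthest is compound 1: a 2.1-fold higher number from compound 1 to compound 3 (0.32 log units; beyond the scatter). Compound 4, `C=Cc1ccc(S(=O)(=O)Nc2ccc3oc(-c4ccccc4)nc3c2)cc1`, is not yet measured in this assay. The structural change from compound 3 to compound 4 is 4-vinylphenyl in place of 3-methylphenyl on a sulfonyl sulfur.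

Two earlier steps bear on this change, since both also exchange the group on the sulfonyl sulfur. The step from compound 1 to compound 3 was modest, and the step from compound 2 to compound 3 stayed within the scatter. Compound 4, like compound 3 and compound 2, carries no hydroxy on that ring, and compound 2 and compound 3 sit together, so the account expects no step beyond the scatter here: a 1.1-fold lower number from compound 3 to compound 4 (0.03 log units; within the scatter). The account therefore estimates that compound 4 will give 65000 nM in this assay, with a likely range from 30000 nM to 130000 nM. The measured value is awaited.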

Compound 4, half-maximal cytotoxic concentration: 53000 nM
Estimate against measurement, compound 4: 1.2-fold (0.09 log units) above, and the stated range covers the measured number.
By their numbers in this assay, from the lowest: compounds 1, 4, 3 and 2 (each within the scatter of the next, the first and the last beyond it).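

In this assay, placing 4-vinylphenyl on the sulfonyl sulfur, with its double bond outside the aromatic ring and 8 heavy atoms against 7 in 3-methylphenyl, gives a 1.3-fold lower number from compound 3 to compound 4 (0.11 log units; within the scatter), so this exchange does not move the number beyond the scatter. The exchange for 2-chlorophenyl gives a 1.4-fold lower number from compound 2 to compound 4 (0.14 log units; within the scatter) and the exchange for 2-hydroxyphenyl gives a 1.6-fold higher number from compound 1 to compound 4 (0.21 log units; within the scatter); compound 4 therefore lies within the scatter of all three earlier compounds, and it goes against reading the gaps that compound 2 and compound 3 each show from compound 1 as holding for every ring without hydroxy. No measurement at hand accounts for any of these steps.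

The compounds shown leave open whether an amine, a carboxylic acid or a longer chain on this ring would stay in the same range of numbers. They also leave open what the vinyl group contributes on its own, since the step from 3-methylphenyl to 4-vinylphenyl changes both the group and where it stands on the ring.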